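The source may report more compounds than this note shows. Statements on the series, on what has been measured and on what is new or still open speak of the compounds shown alone.

For the measured compounds named here, in a functional assay on MDA-MB-231 cells (Homo sapiens) for antiproliferative activity, read by sulforhodamine B assay, with a stated time of 48 h (on this read-out higher numbers stand for weaker inhibition and lower numbers for stronger inhibition), compound 2 `COc1ccc2nc(-c3ccc(N/C=C\C(=O)c4cc(OC)c(OC)c(OC)c4)cc3)sc2c1` gives 19600 nM, the top of the small range of numbers so far, though not separated from compound 1 `COc1ccc2nc(-c3ccc(N/C=C\C(=O)c4cc(OC)c(OC)c(OC)c4)c(C)c3)sc2c1` at 17000 nM. Compound 3 `COc1ccc2nc(-c3ccc(N/C=C\C(=O)c4cc(OC)c(OC)c([N+](=O)[O-])c4)cc3)sc2c1` gives 7610 nM.

Compound 4 `COc1ccc2nc(-c3ccc(N/C=C\C(=O)c4cc(OC)c(OC)c(OC)c4Br)cc3)sc2c1` has bromo in place of hydrogen on an aromatic carbon. The new group stands on the ring that carries the methoxy groups, ortho to a large group.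

Going by the values given here, two measured steps bear on this change. Exchange of a small group on the other aromatic ring, hydrogen in place of methyl, gave a 1.2-fold higher number from compound 1 to compound 2 (0.06 log units; within the scatter). That step shows little response, but it lies on a different ring. Nitro in place of methoxy, on the ring that takes the bromo, gave a 2.6-fold lower number from compound 2 to compound 3 (0.41 log units; beyond the scatter), a modest step. Among the compounds with values here, neither step involves bromo, and no halogen compound has been measured.

On the evidence of these two steps, no more than a small change is expected, most likely within the scatter, with a slight lean towards a lower number. The estimated step is a 1.5-fold lower number from compound 2 to compound 4 (0.18 log units; within the scatter). For compound 4 the expected value is 13000 nM, with an estimated range from 5000 nM to 30000 nM.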

Compound 4, half-maximal inhibitory concentration: 11100 nM
Beside the measured number, compound 4's estimate is 1.2-fold (0.07 log units) above it; the measured number falls inside the stated range.
By their numbers in this assay, from the lowest: compounds 3, 4, 1 and 2 (each within the scatter of the next, the first and the last beyond it).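

In this assay, the aromatic carbon ortho to a large group and ortho to a methoxy group accepts bromo with all three methoxy groups kept, and the step of a 1.8-fold lower number from compound 2 to compound 4 (0.25 log units; within the scatter) cannot be told apart from repeat scatter. Compound 4 is the only compound shown with a substituent on this carbon and the only halogen compound shown, so the series now has a first reading at this position, where a single bromine atom replacing hydrogen gives no clear shift in either direction. No measurement of any property or any other data bears on this result, and the step stands as an observation without an explanation.

From the compounds shown here alone, one halogen at one carbon says little about the position as a whole: whether fluoro, chloro, an amine or a carboxylic acid on this carbon would give a step beyond the scatter stays open. Also open, going by these compounds, is whether bromo here and nitro in place of methoxy, the exchange that gave a 2.6-fold lower number from compound 2 to compound 3 (0.41 log units; beyond the scatter), would add up when both stand on one compound.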